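Swapping the aryl group on the piperazine nitrogen

The source may hold more compounds than are shown below. What is called first, only, known or untested is meant among the compounds shown, and "the series" means these compounds.

Measured compounds:
Compound 1 `CN(C)C(=O)c1cccnc1NCCCN1CCN(c2ccccc2)CC1`: 6.31 nM in a functional assay for antagonist activity at Alpha-1A adrenergic receptor (Oryctolagus cuniculus); a higher number here means weaker binding, a lower number tighter binding
Compound 2 `CC(C)c1ccccc1N1CCN(CCCNc2ncccc2C(=O)N(C)C)CC1`: 0.398 nM

Compound 2 gives the lower of the two numbers in this assay, and the step of a 16-fold lower number from compound 1 to compound 2 (1.20 log units; beyond the scatter) is the only one seen so far. Compound 3 `COc1cc(O)ccc1N1CCN(CCCNc2ncccc2C(=O)N(C)C)CC1` differs from compound 2 by 4-hydroxy-2-methoxyphenyl in place of 2-isopropylphenyl on an amine nitrogen in a ring. Within the data shown here, that step shows the aryl group on this ring nitrogen matters strongly, but no measured pair covers a hydroxy or methoxy there. Compound 3 is expected to lose some of the gain of compound 2, a step of a 6.3-fold higher number from compound 2 to compound 3 (0.80 log units; beyond the scatter), landing at an estimated 2.5 nM within 0.5 nM to 12 nM.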

Compound 3, dissociation constant: 12.6 nM
Beside the measured number, compound 3's estimate is 5.0-fold (0.70 log units) below it; the whole stated range lies below it.
By their numbers in this assay, from the lowest: compound 2; then compounds 1 and 3 (each within the scatter of the next).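

In this assay, the gain seen with 2-isopropylphenyl does not carry over to 4-hydroxy-2-methoxyphenyl, with a 32-fold higher number from compound 2 to compound 3 (1.50 log units; beyond the scatter) at this ring nitrogen. Against the plain phenyl, the new group brings no clear change, with a 2.0-fold higher number from compound 1 to compound 3 (0.30 log units; within the scatter) as the step. Nothing available explains why these aryl groups differ so strongly.

From the compounds shown here alone, the hydroxy and methoxy groups enter together, so their separate contributions remain open. A 2-methoxyphenyl or a 4-hydroxyphenyl group on the same nitrogen would separate them.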